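Pyridazinone sulfonylureas: cyclohexyl for butyl on second core

The compounds below may be only part of what the source reports. "The series", "measured", "known", "first", "only" and "open" are said of these compounds alone.

Measured so far in a functional assay on the whole organism (blood, strain Wistar albino) for inhibition, with Rattus norvegicus as the target, read by colorimetric assay, with stated times of 15 min and 90 min, at a dose of 20 mg/kg by the oral route; on this read-out lower numbers stand for less inhibition and higher numbers for more inhibition at the one dose given (going by the name of the read-out):
compound 1 `CCCCNC(=O)NS(=O)(=O)c1ccc(-n2nc(-c3ccccc3)ccc2=O)cc1`, 67.4%
compound 2 `O=C(NC1CCCCC1)NS(=O)(=O)c1ccc(-n2nc(-c3ccccc3)ccc2=O)cc1`, 52.1%
compound 3 `CCCCNC(=O)NS(=O)(=O)c1ccc(-n2nc(-c3ccc(Cl)cc3)ccc2=O)cc1`, 66%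

Compound 4 `O=C(NC1CCCCC1)NS(=O)(=O)c1ccc(-n2nc(-c3ccc(Cl)cc3)ccc2=O)cc1` is not yet measured. It differs from compound 3 by cyclohexyl in place of butyl on an amide-type nitrogen. The same change is known once already, from compound 1 to compound 2, where it reads cyclohexyl in place of butyl on an amide-type nitrogen and gave a number 15.3 percentage points lower from compound 1 to compound 2 (beyond the scatter). The two cores differ by chloro in place of hydrogen on an aromatic carbon; that change on its own gave a number 1.4 percentage points lower from compound 1 to compound 3 (within the scatter), so compound 1 and compound 3 stand within the scatter of each other and the change is here the same, not merely the same kind, since the place is described identically in both pairs. The expectation for compound 4 therefore rests on the step seen in compound 2: a step of about a number 15 percentage points lower from compound 3 to compound 4 (beyond the scatter) in this assay is expected, because the earlier step was a number 15.3 percentage points lower from compound 1 to compound 2 (beyond the scatter) and the cores behave alike. Compound 4 is accordingly estimated at 51%, between 38% and 62%.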

Compound 4, a percentage reported as inhibition, in the whole organism at one dose (the size of the read-out at that dose, not a potency): 59%
Estimate against measurement, compound 4: 8 percentage points below; measured number inside the range.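

In this assay, cyclohexyl in place of butyl on an amide-type nitrogen gives a number 7 percentage points lower from compound 3 to compound 4 (within the scatter), and the two readings of this change do not differ beyond the scatter: the same change on two cores in this assay, a number 15.3 percentage points lower (beyond the scatter) from compound 1 to compound 2 and a number 7 percentage points lower (within the scatter) from compound 3 to compound 4, 8.3 percentage points apart, within the scatter of two such steps. Chloro in place of hydrogen on an aromatic carbon, read with cyclohexyl in place, gives a number 6.9 percentage points higher from compound 2 to compound 4 (within the scatter), and this change also carries over without a difference that can be told apart: the same change on two cores in this assay, a number 1.4 percentage points lower (within the scatter) from compound 1 to compound 3 and a number 6.9 percentage points higher (within the scatter) from compound 2 to compound 4, 8.3 percentage points apart, within the scatter of two such steps. The four compounds fit a single shared step for each change, but they do not fix its size, since the cyclohexyl step lies beyond the scatter on one core and within it on the other, and two cores make no rule for the series.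

Open, from the compounds shown here alone, are other groups on the amide-type nitrogen, such as hexyl or phenyl. Also open, going by these compounds, are replacements for chloro on the aromatic carbon, such as fluoro or methoxy.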